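Replacing One Ring-Nitrogen Substituent with Another

The source may hold more compounds than are shown below. What is called first, only, known or untested is meant among the compounds shown, and "the series" means these compounds.

Of the compounds shown here, two have so far been measured in a functional assay on isolated protein for agonist activity at Glucose-dependent insulinotropic receptor (Rattus norvegicus), read by HTRF and cAMP accumulation; on this read-out lower numbers stand for an effect already at smaller amounts and higher numbers for an effect only at larger amounts of compound. Compound 1 `CC(C)(C)OC(=O)N1CCC(O[C@H]2CC[C@H](Oc3ccc(S(C)(=O)=O)cc3)CC2)CC1` gives 94 nM. Compound 2 `C[C@H](CF)OC(=O)N1CCC(O[C@H]2CC[C@H](Oc3cnc(S(C)(=O)=O)cn3)CC2)CC1` gives 317 nM, the higher of the two numbers, and its gap to compound 1 lies beyond the usual scatter; as the two differ in more than one place, the numbers alone describe that gap. Compound 3 `CS(=O)(=O)c1cnc(O[C@H]2CC[C@H](OC3CCN(CC4(C(F)(F)F)CCCC4)CC3)CC2)cn1` keeps the core of compound 2 and alters one site only: a group of 10 heavy atoms (7 carbon, 3 fluorine; one five-membered non-aromatic ring of carbon only) in place of a group of 7 heavy atoms (4 carbon, 2 oxygen, 1 fluorine; no ring), on an amine nitrogen in a ring, so a group that carried hydrogen-bond acceptors and a defined stereocentre is exchanged for one with neither. Among the measured compounds shown here, no measured pair shows a change of this kind, so there is no direct guide. The expected step is a 1.6-fold higher number from compound 2 to compound 3 (0.20 log units; within the scatter), a small move towards a higher number that may stay within the scatter. Compound 3 is therefore estimated at 500 nM, with a likely range from 150 nM to 3000 nM.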

Compound 3, half-maximal effective concentration: 101 nM
Compound 3: middle estimate off by 5.0-fold (0.69 log units), on the high side, and the stated range ends above it.
By their numbers in this assay, from the lowest: compounds 1 and 3 (each within the scatter of the next); then compound 2.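

At the amine nitrogen in the six-membered ring, this assay shows a 3.1-fold lower number from compound 2 to compound 3 (0.50 log units; beyond the scatter) when a group carrying hydrogen-bond acceptors and a defined stereocentre gives way to one with a five-membered carbon ring and fluorine. In this one pair, therefore, the number falls even though the entering group has neither acceptors nor a stereocentre, so at this position neither feature is required to reach this level. Nothing measured here explains the step, and the change alters too many features at once for this pair to separate them.

Still open, as far as these compounds go, is which part of the entering group matters: a plain cyclopentylmethyl group without the trifluoromethyl could show this, as could a six-membered carbon ring in place of the five-membered one. From the compounds shown here alone, whether the same exchange gives a similar step on the core of compound 1 also remains open.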